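A benzylic amine in place of a chloroaniline

This account rests on a few compounds, and the source may have more. Where it says the series, first, only, none or still open, it means among the compounds named here.

Of the compounds shown here, three sharing one core have been measured in an assay on cell membranes for binding affinity to adenosine receptor A1 (Bos taurus), read by radioligand binding; a higher number here means a weaker inhibitor, a lower number a stronger inhibitor. Compound 1 `c1ccc(Cn2nnc3c(NCC4CCCCC4)ncnc32)cc1` carries a cyclohexylmethyl group on the ring nitrogen and gives 2790 nM. Compound 2 `O=[N+]([O-])c1cccc(Nc2ncnc3c2nnn3Cc2ccccc2)c1` carries a nitrophenyl group there and gives 443 nM. Compound 3 `Clc1cccc(Nc2ncnc3c2nnn3Cc2ccccc2)c1` carries a chlorophenyl group and gives 463 nM, so compound 3 sits close to compound 2 and well away from compound 1: the step of a 1.0-fold higher number from compound 2 to compound 3 (0.02 log units; within the scatter) is negligible, while the step of a 6.0-fold lower number from compound 1 to compound 3 (0.78 log units; beyond the scatter) is clear.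

Compound 4 `Nc1ccc(CNc2ncnc3c2nnn3Cc2ccccc2)cc1` differs from compound 3 in one place: 4-aminobenzyl in place of 3-chlorophenyl on a nitrogen on an aromatic ring. The step that bears on this change is a 6.0-fold lower number from compound 1 to compound 3 (0.78 log units; beyond the scatter), which showed that a group joined to the nitrogen through a saturated carbon, rather than an aromatic ring attached directly, gives a markedly higher number in this assay. Compound 4 again has a saturated carbon between the nitrogen and the ring, so a rise in the number is expected, though the aromatic ring and its amino group leave the size of that rise uncertain. The expected step is a 3.2-fold higher number from compound 3 to compound 4 (0.51 log units; beyond the scatter). For compound 4 the estimated value in this assay is 1500 nM, with a range from 500 nM to 5000 nM.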

Compound 4, inhibition constant: 9500 nM
The estimate for compound 4 lay 6.3-fold (0.80 log units) below the measured number; the whole stated range lies below it.
By their numbers in this assay, from the lowest: compounds 2 and 3 (each within the scatter of the next); then compound 1; then compound 4.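

In this assay the change to 4-aminobenzyl on this nitrogen gives a 21-fold higher number from compound 3 to compound 4 (1.31 log units; beyond the scatter) and so costs more than the cyclohexylmethyl group of compound 1 did. With the saturated chain carbon kept in place, 4-aminophenyl in place of cyclohexyl gives a 3.4-fold higher number from compound 1 to compound 4 (0.53 log units; beyond the scatter) and this shows that an aromatic ring on that carbon does not bring the number back towards that of compound 3 but takes it further away. At this position, then, both groups joined through a saturated carbon give higher numbers than compound 3, and what sits on that carbon matters as well, though nothing available here explains the rise.

From the compounds shown here alone, the step to compound 4 swaps the joining carbon and the ring's substituent at once, so the share of each stays unknown, and a plain benzyl group on this nitrogen would help to separate them. Going by these compounds, it also stays open whether the amine of the 4-aminobenzyl group or its aromatic ring drives the higher number, a question that a hydroxyl group on that ring or a longer chain to the ring could begin to answer.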